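The source may report more compounds than this note shows. Statements on the series, on what has been measured and on what is new or still open speak of the compounds shown alone.

Compound 1 `C=CC(=O)Nc1ccc(Cn2nc(-c3ccc(Oc4ccccc4)cc3)cc2C(=O)O)cc1`: > 60000 nM, a limit of the assay and not a number.
Compound 2 `C=CC(=O)Nc1ccc(Cn2nc(-c3ccc(Oc4ccccc4)cc3)cc2C(=O)OCC)cc1`: 12500 nM.
Compound 3 `C=CC(=O)Nc1ccc(Cn2nc(-c3ccc(Oc4ccccc4)cc3)cc2CO)cc1`: 6800 nM.

All three were tested in a functional assay on Z-138 cells (Homo sapiens) for inhibition, read by luminescence and CellTiter-Glo, with a stated time of 72 h; on this read-out higher numbers stand for weaker inhibition and lower numbers for stronger inhibition. Two of them give true numbers, and these cannot be told apart: a 1.8-fold lower number from compound 2 to compound 3 (0.26 log units; within the scatter). Among the compounds with values here, compound 2 therefore stands level with its only measured neighbour, while compound 1 is known only through its limit.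

Compound 4 `CCOC(=O)c1cc(-c2ccc(Oc3ccccc3)cc2)nn1Cc1ccc(NC(=O)CCl)cc1` is still to be measured. It keeps the ethoxycarbonyl group of compound 2 and differs in one place: chloromethyl in place of vinyl on a carbonyl carbon. In words, chloromethyl replaces vinyl on a carbonyl carbon.

The two larger measured steps are an at least 4.8-fold lower number from compound 1 to compound 2 (0.68 log units; beyond the scatter) and an at least 8.8-fold lower number from compound 1 to compound 3 (0.94 log units; beyond the scatter). Both, like the smaller step, change a different group and leave the vinyl untouched, so none of the three measures this swap directly. With no measured guide for this change, no shift beyond the scatter is expected in this assay, though the uncertainty is wide. The expected step is a 1.6-fold lower number from compound 2 to compound 4 (0.19 log units; within the scatter). For compound 4 the estimate is 8000 nM, with an expected range of 2500 nM to 30000 nM.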

Compound 4, half-maximal inhibitory concentration: 400 nM
Estimate against measurement, compound 4: 20-fold (1.30 log units) above; measured number outside the range, below it.
By their numbers in this assay, from the lowest: compound 4; then compounds 3 and 2 (each within the scatter of the next). At a limit, above all of these: compound 1.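

In this assay, chloromethyl in place of vinyl on a carbonyl carbon gives a 31-fold lower number from compound 2 to compound 4 (1.49 log units; beyond the scatter), so this place in the molecule has a large influence on the read-out. Compounds 1, 2 and 3 all carry vinyl here, so they could show nothing about it. The ethoxycarbonyl group and the rest of the core stay the same in this step, so the whole difference belongs to this one exchange of groups.

Going by these compounds, it remains open whether the same exchange would have a similar effect with carboxy or hydroxymethyl in place of ethoxycarbonyl, and how a bromomethyl or a plain methyl group would behave on this carbonyl carbon. Nothing measured here explains why this exchange has so large an effect.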